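The source may hold more compounds than are shown below. What is called first, only, known or untested is meant among the compounds shown, and "the series" means these compounds.

Three measured compounds stand at the start:

compound 1, `COc1ccc(-c2nc3c(NC4CCCC4)ncnc3n2C)cc1`, which in an assay on CHO cells for displacement of a labelled ligand from adenosine receptor A1 (Homo sapiens), read by scintillation counting, with a stated time of 3 h (on this read-out higher numbers stand for weaker inhibition and lower numbers for stronger inhibition), gives 75 nM
compound 2, `CCn1c(-c2ccccc2)nc2c(NC3CCC3)ncnc21`, which in this assay gives 6 nM
compound 3, `CCn1c(-c2ccccc2)nc2c(NC3CCOC3)ncnc21`, which in this assay gives 10 nM

Compound 1 holds the highest number of the three in this assay. Compound 3 is nearest to it and still sits clearly lower, beyond the scatter, and compound 2 lies lower still, also beyond the scatter. Within the data shown here, the one step between neighbours that differ in a single place, a 1.7-fold higher number from compound 2 to compound 3 (0.22 log units; within the scatter), concerns the ring on the amine nitrogen and stays within the scatter.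

Compound 4, `Cn1c(-c2ccc(Cl)cc2)nc2c(NC3CCCC3)ncnc21`, has not yet been measured in this assay. It differs from compound 1 by chloro in place of methoxy on an aromatic carbon. Among the measured compounds shown here, no measured step bears on this change: the only step available, a 1.7-fold higher number from compound 2 to compound 3 (0.22 log units; within the scatter), touches a different place in the molecule, and compounds 2 and 3 differ from compound 1 in more than one place, so their values show only that the lower numbers in this set belong to compounds with a different ring on the amine nitrogen and a different group on the other nitrogen. For compound 4 the step from compound 1 is therefore expected to be a 1.4-fold lower number from compound 1 to compound 4 (0.13 log units; within the scatter), with no clear direction beyond the scatter. Compound 4 is estimated at 55 nM, somewhere between 15 nM and 200 nM.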

Compound 4, inhibition constant: 18 nM
Estimate against measurement, compound 4: 3.1-fold (0.49 log units) above; measured number inside the range.
By their numbers in this assay, from the lowest: compounds 2, 3 and 4 (each within the scatter of the next, the first and the last beyond it); then compound 1.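

In this assay, the change from 4-methoxyphenyl to 4-chlorophenyl gives a 4.2-fold lower number from compound 1 to compound 4 (0.62 log units; beyond the scatter), a modest step but one that lies beyond the scatter. Among these compounds, the only earlier step concerned the ring on the amine nitrogen and stayed within the scatter, so this is the first single change in the set to shift the number clearly, and it shows that the aromatic carbon para to a large group is a place where exchanging methoxy for chloro registers in this read-out, with the rest of compound 1 unchanged. Nothing in the data shown accounts for the size or direction of this step.

On these data alone, what a fluoro, a methyl, a trifluoromethyl, a nitrile or an amine would do on this same aromatic carbon remains open, so this single pair cannot show whether the step follows from methoxy leaving or from chloro entering. As far as these compounds go, it also remains open whether the same exchange would give a step of similar size on the phenyl ring of compound 2 or compound 3, which carry a different ring on the amine nitrogen and a different group on the other nitrogen.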